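This account rests on a few compounds, and the source may have more. Where it says the series, first, only, none or still open, it means among the compounds named here.

Compound 3 `CC(C(=O)NCc1ccc(C(F)(F)F)nc1N1CCC(C(F)(F)F)CC1)c1ccc(NS(C)(=O)=O)c(F)c1` gives the lowest number of the three measured in a functional assay on CHO-K1 cells for antagonist activity at transient receptor potential cation channel subfamily V member 1 (Homo sapiens), read by FLIPR (on this read-out lower numbers stand for stronger inhibition and higher numbers for weaker inhibition), at 0.6 nM. Compound 1 `CC(C(=O)NCc1ccc(C(F)(F)F)nc1Nc1ccc(F)cc1)c1ccc(NS(C)(=O)=O)c(F)c1` gives 39.2 nM in this assay, and compound 2 `CC(C(=O)NCc1ccc(C(F)(F)F)nc1N1CCC(C(=O)c2ccc(F)cc2)CC1)c1ccc(NS(C)(=O)=O)c(F)c1` gives 3.9 nM. Both steps into compound 3 lie beyond the scatter: a 65-fold lower number from compound 1 to compound 3 (1.82 log units; beyond the scatter) and a 6.5-fold lower number from compound 2 to compound 3 (0.81 log units; beyond the scatter).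

Compound 4 `CC(=O)OC1CCN(c2nc(C(F)(F)F)ccc2CNC(=O)C(C)c2ccc(NS(C)(=O)=O)c(F)c2)CC1` is not yet measured and differs from compound 3 in one place: acetoxy in place of trifluoromethyl on a saturated ring carbon. Within the data shown here, of the measured steps, only one touches this saturated ring carbon, namely a 6.5-fold lower number from compound 2 to compound 3 (0.81 log units; beyond the scatter), where (4-fluorophenyl)carbonyl gave way to trifluoromethyl. Among the measured compounds shown here, the present step removes that trifluoromethyl again, but acetoxy rather than (4-fluorophenyl)carbonyl enters, and no measured pair shows acetoxy at this position. The step on the aromatic carbon, a 65-fold lower number from compound 1 to compound 3 (1.82 log units; beyond the scatter), concerns a different place and is taken only as a sign that this region of the core responds strongly in this assay.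

Because a 6.5-fold lower number from compound 2 to compound 3 (0.81 log units; beyond the scatter) was modest, the expected change is a rise in the number of about the same size or somewhat smaller. The expected step is a 4.2-fold higher number from compound 3 to compound 4 (0.62 log units; beyond the scatter). In this assay compound 4 is therefore expected to give about 2.5 nM, within a range from 0.8 nM to 8 nM.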

Compound 4, inhibition constant: 4 nM
Compound 4: middle estimate off by 1.6-fold (0.20 log units), on the low side; low and high end bracket the measured number.
By their numbers in this assay, from the lowest: compound 3; then compounds 2 and 4 (each within the scatter of the next); then compound 1.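

In this assay, among these compounds, a 6.7-fold higher number from compound 3 to compound 4 (0.82 log units; beyond the scatter) shows that at this saturated ring carbon an exchange of trifluoromethyl for acetoxy, with the same count of heavy atoms on each side, still shifts the number beyond the scatter, so heavy-atom count alone does not set the value in this pair, while a 1.0-fold higher number from compound 2 to compound 4 (0.01 log units; within the scatter) shows that acetoxy and (4-fluorophenyl)carbonyl cannot be told apart here, leaving trifluoromethyl as the only one of the three groups at this carbon that stands apart from the others. On the aromatic carbon, a 9.8-fold lower number from compound 1 to compound 4 (0.99 log units; beyond the scatter) shows that 4-acetoxypiperidin-1-yl also gives a lower number than (4-fluorophenyl)amino, so all three piperidine compounds now lie below compound 1, by differing margins. No measurement at hand explains why these groups differ at this position.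

On these data alone, whether a hydroxyl, a primary amine or a carboxylic acid on this carbon would group with compound 3 or with compounds 2 and 4 remains open. Also open, as far as these compounds go, is whether an ester with a longer chain than acetoxy would move the number at all.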